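Methoxy for fluoro on the pendant phenyl

The source may hold more compounds than are shown below. What is called first, only, known or untested is meant among the compounds shown, and "the series" means these compounds.

Measured so far:
compound 1 `COc1ccc(-c2cc(C(=O)Nc3nc4ccc(Cl)cc4s3)nc3cc(-c4ccccc4)nn23)cc1`, 7240 nM
compound 2 `O=C(Nc1nc2ccc(F)cc2s1)c1cc(-c2ccc(F)cc2)n2nc(-c3ccccc3)cc2n1`, 35500 nM

In a functional assay on ACHN cells (Homo sapiens) for cytotoxicity, read by MTT assay, with a stated time of 48 h (a lower number here means a stronger inhibitor, a higher number a weaker inhibitor), compound 2 stands with the highest number of the two; its nearest neighbour, compound 1, gives 7240 nM, a gap that lies beyond the scatter. Compound 3 `COc1ccc(-c2cc(C(=O)Nc3nc4ccc(F)cc4s3)nc3cc(-c4ccccc4)nn23)cc1` is not yet measured. It differs from compound 2 by methoxy in place of fluoro on an aromatic carbon, so that the 4-fluorophenyl becomes the 4-methoxyphenyl that compound 1 also carries. Among the compounds with values here, no pair that differs only in this place has been measured, so the size of the step rests on expectation alone. The step from compound 2 to compound 3 is expected to give a lower number, estimated at a 3.0-fold lower number from compound 2 to compound 3 (0.47 log units; beyond the scatter), because compound 1 gives 7240 nM with the same 4-methoxyphenyl. Compound 3 is therefore expected at 12000 nM, with a range from 4000 nM to 36000 nM.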

Compound 3, half-maximal inhibitory concentration: 39300 nM
Beside the measured number, compound 3's estimate is 3.3-fold (0.52 log units) below it, and the stated range ends below it.
By their numbers in this assay, from the lowest: compound 1; then compounds 2 and 3 (each within the scatter of the next).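

In this assay, the first pair differing only at the pendant phenyl reads a 1.1-fold higher number from compound 2 to compound 3 (0.04 log units; within the scatter), so 4-fluorophenyl to 4-methoxyphenyl gives no difference that can be told from the scatter while the other ring carries fluoro. The 4-methoxyphenyl alone therefore does not account for the number of compound 1. With the 4-methoxyphenyl held constant, fluoro in place of chloro on an aromatic carbon gives a 5.4-fold higher number from compound 1 to compound 3 (0.73 log units; beyond the scatter), which places the visible change at that other site, on the evidence of this single pair.

No measurement offered here bears on the reason for either step. Going by these compounds, whether the flat reading at the pendant phenyl holds with chloro on the other ring, or with an amine or a carboxylic acid at the same place, remains open.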